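Methyl on the Phenol Oxygen: Two Matched Steps

This account rests on a few compounds, and the source may have more. Where it says the series, first, only, none or still open, it means among the compounds named here.

Compound 1 `O=C(Nc1cccc(-n2cc(-c3ccncc3)c(-c3cc(O)cc(Cl)c3)n2)c1)Nc1ccc(Cl)c(Cl)c1` gives 10.7% in a functional assay on OVCAR-4 cells (Homo sapiens) for inhibition, read by sulforhodamine B assay, with a stated time of 48 h, tested at 10 uM; on this read-out lower numbers stand for a stronger effect and higher numbers for a weaker effect at the one concentration tested. Compound 2 `COc1cc(Cl)cc(-c2nn(-c3cccc(NC(=O)Nc4ccc(Cl)c(Cl)c4)c3)cc2-c2ccncc2)c1` gives 13.3% in this assay; the step of a number 2.6 percentage points higher from compound 1 to compound 2 (within the scatter) arises from methyl in place of hydrogen on an oxygen on an aromatic ring. Compound 3 `O=C(Nc1cccc(-n2cc(-c3ccncc3)c(-c3cc(O)cc(Cl)c3)n2)c1)c1cc(C(F)(F)F)cc(C(F)(F)F)c1` gives 59.6% in this assay, the highest of the three numbers, beyond the scatter from both others; the difference between the cores of compound 1 and compound 3 is not broken down here. Compound 4 `COc1cc(Cl)cc(-c2nn(-c3cccc(NC(=O)c4cc(C(F)(F)F)cc(C(F)(F)F)c4)c3)cc2-c2ccncc2)c1` has not yet been measured. It differs from compound 3 by methyl in place of hydrogen on an oxygen on an aromatic ring, the same change as between compound 1 and compound 2, at a place described in the same words. Because the earlier step of a number 2.6 percentage points higher from compound 1 to compound 2 (within the scatter) lay within the scatter, the expected step is likewise small, a number 2.4 percentage points higher from compound 3 to compound 4 (within the scatter). Compound 4 is therefore estimated at 62% in this assay, between 45% and 78%.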

Compound 4, a percentage reported as activity, at one concentration (the size of the read-out at that concentration, not a potency): 72.1%
Beside the measured number, compound 4's estimate is 10.1 percentage points below it; the range from low to high includes it.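

On the core of compound 3, the change from hydroxy to methoxy gives a number 12.5 percentage points higher from compound 3 to compound 4 (beyond the scatter) in this assay. Set beside the earlier step, the result does not separate the two cores: the same change on two cores in this assay, a number 2.6 percentage points higher (within the scatter) from compound 1 to compound 2 and a number 12.5 percentage points higher (beyond the scatter) from compound 3 to compound 4, 9.9 percentage points apart, within the scatter of two such steps. This shows that the change carried over without a measurable difference in step size between these two pairs, but two pairs cannot establish a constant step across the series, and the data do not explain why only the second step lies beyond the scatter.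

The compounds shown leave open how a longer chain such as ethyl on that oxygen, or an amine in place of the hydroxy, would read in this assay. They also leave open whether the same step would hold on any further core.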